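The source may report more compounds than this note shows. Statements on the series, on what has been measured and on what is new or still open speak of the compounds shown alone.

Measured so far:
compound 1, `CCCc1c(COc2ccc(C(=O)CCc3nnn[nH]3)cc2)ccc(C(C)=O)c1O`, 7.09
compound 2, `CCCc1c(COc2ccc(C(=O)C(C)(C)Cc3nnn[nH]3)cc2)ccc(C(C)=O)c1O`, 6.93

Both numbers come from a functional assay on ileum (Cavia porcellus) with cysteinyl leukotriene receptor (Homo sapiens) as the target; on this read-out lower numbers stand for lower potency and higher numbers for higher potency (the scale is a negative logarithm). In that assay compound 2 gives 6.93, and compound 1 gives 7.09. The step of a number 0.16 log units lower from compound 1 to compound 2 (within the scatter) is within the scatter, so the two compounds stand level; compound 2 holds the smaller of the two numbers, with compound 1 nearest, but that gap carries no weight.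

Compound 3, `CCCc1c(COc2ccc(C(=O)CCCc3nnn[nH]3)cc2)ccc(C(C)=O)c1O`, has not yet been measured. It differs from compound 2 in one place: 3-(1H-tetrazol-5-yl)propyl in place of 1-((1H-tetrazol-5-yl)methyl)-1-methylethyl on a carbonyl carbon. Part of this change undoes the one measured step: the methyl groups that came in from compound 1 to compound 2 leave again, and that step, a number 0.16 log units lower from compound 1 to compound 2 (within the scatter), was within the scatter. The other part, the longer chain between the carbonyl and the tetrazole ring, has no measured counterpart among these compounds. With only a step within the scatter to lean on, the expected step in this assay is a number 0.07 log units higher from compound 2 to compound 3 (within the scatter), none beyond the scatter. Compound 3 is therefore estimated at 7, with a range from 6.4 to 7.6.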

Compound 3, negative logarithm of the antagonist equilibrium constant: 7.67
Estimate against measurement, compound 3: 0.67 log units below, outside the stated range (above it).
By their numbers in this assay, from the lowest: compounds 2 and 1 (each within the scatter of the next); then compound 3.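

Until now, changes at this position on the carbonyl carbon had moved nothing beyond the scatter, but chain length turns out to matter: in this assay, replacing the shorter 2-(1H-tetrazol-5-yl)ethyl chain with the longer 3-(1H-tetrazol-5-yl)propyl chain gives a number 0.58 log units higher from compound 1 to compound 3 (beyond the scatter). The other new step, a number 0.74 log units higher from compound 2 to compound 3 (beyond the scatter), is also beyond the scatter, but it removes the methyl groups and lengthens the chain in a single change, so the comparison with compound 1 is the cleaner reading of chain length alone. Nothing available here explains why the longer chain gives the higher number.

The compounds shown leave open whether the trend continues with a still longer chain, such as 4-(1H-tetrazol-5-yl)butyl, or reverses, since two chain lengths without methyl groups cannot define an optimum. They also leave open whether the methyl groups would be tolerated on the longer chain as they were on the shorter one, and whether a carboxylic acid could stand in place of the tetrazole ring at the end of the chain.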